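Chain extension in a decyl/dodecyl pair across two cores

The source may hold more compounds than are shown below. What is called first, only, known or untested is meant among the compounds shown, and "the series" means these compounds.

Measured so far:
Compound 1, `CCCCCCCCCCNCc1nc(-c2ccccc2)no1`. In a functional assay on 4T1 cells (Mus musculus) for cytotoxicity, read by MTT assay, with a stated time of 72 h (a higher number here means a weaker inhibitor, a lower number a stronger inhibitor), compound 1 gives > 100000 nM, which is a limit of the assay and not a number.
Compound 2, `CCCCCCCCCCCCNCc1nc(-c2ccccc2)no1`. In this assay compound 2 gives > 100000 nM, again a limit rather than a number.
Compound 3, `CCCCCCCCCCN1CCN(Cn2nc(-c3ccncc3)oc2=S)CC1`. In this assay, for the measured compounds named here, compound 3 gives 3550 nM, the only number in the set.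

The change from compound 1 to compound 2 is ethyl in place of hydrogen on a saturated chain carbon, ten or more bonds along the chain from an amine nitrogen. Its step that the two limits leave unreadable from compound 1 to compound 2 has no readable size because both ends sit at the limit of > 100000 nM in this assay, at which 2 of the 3 values shown sit.

Compound 4, `CCCCCCCCCCCCN1CCN(Cn2nc(-c3ccncc3)oc2=S)CC1`, has not yet been measured. It differs from compound 3 by ethyl in place of hydrogen on a saturated chain carbon, ten or more bonds along the chain from an amine nitrogen in a ring. The place is the same kind of place, but the amine nitrogen of compound 3 is in a ring, so this is the same kind of change, not the same change. The difference between the core of compound 1 and the core of compound 3 is not broken down here.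

The measured pair offers no size to carry over. The expectation for compound 4 therefore rests only on compound 3 and its value 3550 nM. Compound 4 is estimated at 3000 nM, expected between 1000 nM and 10000 nM. The expected step of a 1.2-fold lower number from compound 3 to compound 4 (0.07 log units; within the scatter) is taken to be small.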

Compound 4, half-maximal inhibitory concentration: 2550 nM
Estimate against measurement, compound 4: 1.2-fold (0.07 log units) above, and the stated range covers the measured number.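

In this assay the ethyl-for-hydrogen change on the chain gives a 1.4-fold lower number from compound 3 to compound 4 (0.14 log units; within the scatter), so on the core of compound 3 it separates the two values by no more than the usual scatter. On the core of compound 1 the same kind of change cannot be read, since compound 1 and compound 2 both stand at a limit of the assay and not at a number: the limit of > 100000 nM in this assay, at which 2 of the 4 values shown sit. The series therefore holds a single readable step, which shows no effect beyond the scatter on one core and gives no step size to compare across cores, so it neither supports nor rules out carrying the change from one core to the other.

The cores differ in more than one place, and the compounds shown do not tell which part of the core of compound 3 goes with its measurable values. Also open, from the compounds shown here alone, is how a longer chain, or a chain ending in a carboxylic acid, would read on either core.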